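The source may hold more compounds than are shown below. What is called first, only, known or untested is meant among the compounds shown, and "the series" means these compounds.

In a functional assay on cells for antagonist activity at C-X-C chemokine receptor type 4 (Homo sapiens), read by fluorescence and calcium flux, with stated times of 25 min and 90 s (a lower number here means a stronger inhibitor, a higher number a weaker inhibitor), the three measured compounds stand as follows:

- compound 1, `FC1(F)CCC(NCc2ccc(CN(C[C@H]3Cc4ccccc4CN3)[C@H]3CCCc4cccnc43)cc2)CC1`: 143 nM
- compound 2, `c1ccc2c(c1)CN[C@@H](CN(Cc1ccc(CNC3CCOCC3)cc1)[C@H]1CCCc3cccnc31)C2`: 90.3 nM
- compound 3, `CC(C)(CCN(C[C@H]1Cc2ccccc2CN1)[C@H]1CCCc2cccnc21)CNC1CCC(F)(F)CC1`: 168 nM

Compound 1 and compound 2 share one core and differ by oxan-4-yl in place of 4,4-difluorocyclohexyl on an amine nitrogen. That change gave a 1.6-fold lower number from compound 1 to compound 2 (0.20 log units; within the scatter), a step within the scatter, so the two numbers are not separated by this assay. Compound 3 has a different core; the difference between the two cores is not broken down here. Its value sits within the scatter of compound 1 and of compound 2.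

Compound 4, `CC(C)(CCN(C[C@H]1Cc2ccccc2CN1)[C@H]1CCCc2cccnc21)CNC1CCOCC1`, is the counterpart of compound 3: it differs from compound 3 by oxan-4-yl in place of 4,4-difluorocyclohexyl on an amine nitrogen. The place is the same word for word as in the pair of compound 1 and compound 2, so this is the same change made on the other core. Going by the values given here, the only guide to its size is the single measured pair, because a 1.6-fold lower number from compound 1 to compound 2 (0.20 log units; within the scatter) is the one instance of this change seen so far. An equally small step, a 1.5-fold lower number from compound 3 to compound 4 (0.18 log units; within the scatter), is expected from compound 3 to compound 4. Compound 4 is estimated at 110 nM in this assay, with a range of 55 nM to 220 nM.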

Compound 4, half-maximal inhibitory concentration: 36.3 nM
Beside the measured number, compound 4's estimate is 3.0-fold (0.48 log units) above it; measured number outside the range, below it.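

In this assay, oxan-4-yl in place of 4,4-difluorocyclohexyl on an amine nitrogen gave a 4.6-fold lower number from compound 3 to compound 4 (0.67 log units; beyond the scatter), a step this assay does separate. The same change did not give one step size on the two cores: the same change on two cores in this assay, a 1.6-fold lower number (0.20 log units; within the scatter) from compound 1 to compound 2 and a 4.6-fold lower number (0.67 log units; beyond the scatter) from compound 3 to compound 4, 2.9-fold (0.47 log units) apart, beyond the scatter of two such steps

Going by these compounds alone, the size of this change on the core of compound 1 is therefore no reliable guide to its size on the core of compound 3, and a step read on one core should not simply be carried to the other; what this does not show is which part of the two cores sets the gap, or whether the gap would hold for any other change, since only one pair per core stands behind it.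

Open, as far as these compounds go, is whether a plain cyclohexyl or a piperidin-4-yl on the same amine nitrogen would also give steps that differ between the two cores. Also open, from the compounds shown here alone, is which of the differences between the two cores matters, which would take a core lying between them and carrying the same two groups.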